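A few compounds are considered here, and "the series" means these few. Any claim that something is new, unique, unknown or untested is made for them only; others in the source may bear on it.

Three compounds share one core and differ only in the aryl on the carbonyl carbon. In an ADME assay on HEK-293T cells (Homo sapiens) for cytotoxicity, read by MTT assay, with a stated time of 24 h (on this read-out lower numbers stand for higher toxicity in this test and higher numbers for lower toxicity in this test), compound 1 `Cc1ccccc1C(=O)n1c(-c2cn(-c3ccccc3)nc2-c2ccc(F)cc2)nc2ccccc21` gives 189000 nM, and compound 3 `O=C(c1cccnc1)n1c(-c2cn(-c3ccccc3)nc2-c2ccc(F)cc2)nc2ccccc21` gives 216000 nM in this assay, so the step of a 1.1-fold higher number from compound 1 to compound 3 (0.06 log units; within the scatter) lies within the scatter. Compound 2 `Cc1ccc(-c2nn(-c3ccccc3)cc2-c2nc3ccccc3n2C(=O)c2ccc(C)nc2)cc1` gives 145000 nM in this assay, the lowest of the three numbers, though its gaps to compound 1 and to compound 3 both lie within the scatter. Compound 4 `Cc1ccc(-c2nn(-c3ccccc3)cc2-c2nc3ccccc3n2C(=O)c2ccncc2)cc1` carries pyridin-4-yl in place of 6-methylpyridin-3-yl on a carbonyl carbon. For the measured compounds named here, the one measured step at that place, a 1.1-fold higher number from compound 1 to compound 3 (0.06 log units; within the scatter), changed the number hardly at all, so no step beyond the scatter is expected here. Compound 4 is therefore expected to give 150000 nM, between 75000 nM and 300000 nM, an expected step of a 1.0-fold higher number from compound 2 to compound 4 (0.01 log units; within the scatter).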

Compound 4, half-maximal cytotoxic concentration: 154000 nM
For compound 4 the middle estimate is 1.0-fold (0.01 log units) below the measured one; low and high end bracket the measured number.
By their numbers in this assay, from the lowest: compounds 2, 4, 1 and 3 (each within the scatter of the next).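

In this assay, a second exchange at this carbonyl carbon, a 1.1-fold higher number from compound 2 to compound 4 (0.03 log units; within the scatter), also lies within the scatter, and it does so on the core of compound 2 rather than that of compound 1. Two different aryl exchanges at this place, on two cores, have now left the number within the scatter, and nothing available explains this. Going by these compounds, all four compounds carry a six-membered aromatic ring on the carbonyl carbon, so it stays open whether an amine, a carboxylic acid or a longer alkyl chain there would give a step beyond the scatter.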